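Turning One Double Bond from Z to E

A few compounds are considered here, and "the series" means these few. Any claim that something is new, unique, unknown or untested is made for them only; others in the source may bear on it.

In a functional assay on M21 cells (Homo sapiens) for inhibition, read by sulforhodamine B assay, with a stated time of 48 h (a lower number here means a stronger inhibitor, a higher number a weaker inhibitor), compound 2 `CCNC(=O)Nc1ccc(/C=C\c2cc(OC)c(OC)c(OC)c2)cc1` gives 21000 nM. That number lies within the usual scatter of both neighbours: compound 1 `CCNC(=O)Nc1ccc(/C=C\c2cccc(Cl)c2)cc1` gives 35000 nM and compound 3 `Cc1cc(C)cc(/C=C/c2ccc(N3CCNC3=O)cc2)c1` gives 17000 nM. So compound 2 cannot be told apart from either of them.

Compound 4 `CCNC(=O)Nc1ccc(/C=C/c2cc(OC)c(OC)c(OC)c2)cc1` has the same atoms and bonds as compound 2 and differs only in configuration as drawn (the two compounds have the same atoms and bonds and differ only in configuration as drawn: 1 of 1 stereo elements differ; a double bond is drawn Z in compound 2 and E in compound 4): a double bond is drawn Z in compound 2 and E in compound 4. Within the data shown here, no measured pair here isolates this change, so its effect cannot be read directly. The nearest hint is compound 3, whose double bond is drawn E and whose 17000 nM stays within the scatter of compound 2, although the two also differ elsewhere. On that thin evidence, no shift beyond the scatter is expected. The expected change is a 1.1-fold lower number from compound 2 to compound 4 (0.02 log units; within the scatter). For compound 4 the estimated value is 20000 nM, with an expected range from 8000 nM to 50000 nM.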

Compound 4, half-maximal inhibitory concentration: 29000 nM
For compound 4 the middle estimate is 1.5-fold (0.16 log units) below the measured one; the range from low to high includes it.
By their numbers in this assay, from the lowest: compounds 3, 2, 4 and 1 (each within the scatter of the next, the first and the last beyond it).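

The earlier compounds shown here offered only a hint about the geometry of this double bond, as compound 3 also differs from compound 2 elsewhere. This pair gives a direct reading, and it is clean because of one thing: the fact that compounds 2 and 4 differ only in the configuration as drawn. In this assay the step is a 1.4-fold higher number from compound 2 to compound 4 (0.14 log units; within the scatter), so the Z and E forms of this pair cannot be told apart, although one pair cannot speak for compound 1, whose Z double bond has no E partner among the compounds shown.

From the compounds shown here alone, it remains open whether the two forms would also read alike with another group, such as an amine or a carboxylic acid, in place of the chloro group of compound 1. Also open, going by these compounds, is how this pair would read with a single bond in place of the double bond.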